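From Methoxy to Fluoro: A Single Swap

This account rests on a few compounds, and the source may have more. Where it says the series, first, only, none or still open, it means among the compounds named here.

In a functional assay on SW620/5-FU cells (Homo sapiens) for cytotoxicity, read by MTT assay, with a stated time of 48 h, in the presence of a further agent that is not named here (on this read-out higher numbers stand for an effect only at larger amounts of compound and lower numbers for an effect already at smaller amounts), compound 1 `CCN(CC)c1cc(NC(=O)NNc2cc(-c3ccc(F)cc3)c3cnn(C)c3n2)cc(Cl)n1` gives 37000 nM and compound 2 `COc1ccc(-c2cc(NNC(=O)Nc3cc(Cl)nc(OC)c3)nc3c2cnn3C)cc1` gives 48800 nM. These two numbers lie within the usual scatter of repeated measurements, so they are best read as the same result.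

Compound 3 `COc1cc(NC(=O)NNc2cc(-c3ccc(F)cc3)c3cnn(C)c3n2)cc(Cl)n1` differs from compound 2 in one place: fluoro in place of methoxy on an aromatic carbon. Seen one bond further out, the same swap turns 4-methoxyphenyl into 4-fluorophenyl.

Among the compounds with values here, no measured pair shows this change on its own, so the data give no direct size for it. In this assay, no shift beyond the scatter is expected, and the estimated change is a 1.2-fold lower number from compound 2 to compound 3 (0.09 log units; within the scatter). Within the data shown here, the only guide is how closely the two measured compounds agree. For compound 3 the estimated value is 40000 nM, with an expected range from 15000 nM to 90000 nM.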

Compound 3, half-maximal effective concentration: 24100 nM
For compound 3 the middle estimate is 1.7-fold (0.22 log units) above the measured one; measured number inside the range.
By their numbers in this assay, from the lowest: compounds 3, 1 and 2 (each within the scatter of the next, the first and the last beyond it).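

In this assay this change now has a size of its own: going from 4-methoxyphenyl to 4-fluorophenyl gives a 2.0-fold lower number from compound 2 to compound 3 (0.31 log units; beyond the scatter) as a modest step, only just past the usual scatter. Compound 3 also allows a look at a second place, where methoxy in place of diethylamino on an aromatic carbon gives a 1.5-fold lower number from compound 1 to compound 3 (0.19 log units; within the scatter) and so leaves those two groups indistinguishable in this test. Nothing at hand explains either step.

One step cannot show how a group such as chloro, hydroxyl or an amine would compare at the place of the fluoro. As far as these compounds go, it also stays open whether the swap from methoxy to fluoro would give a step of the same size with diethylamino at the second place.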